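A few compounds are considered here, and "the series" means these few. Any claim that something is new, unique, unknown or untested is made for them only; others in the source may bear on it.

In a functional assay on BT-20 cells (Homo sapiens) for cytotoxicity, read by MTT assay, with a stated time of 68 h (on this read-out higher numbers stand for weaker inhibition and lower numbers for stronger inhibition), compound 2 `O=C(/C=C/c1cccc(OCc2ccccc2)c1)c1ccc([N+](=O)[O-])cc1` gives 80900 nM, the higher of the two numbers at hand, while compound 1 `O=C(/C=C/c1cccc(OCc2ccccc2)c1)c1cccc(Br)c1` gives 7100 nM. Within the data shown here, the one measured step is an 11-fold higher number from compound 1 to compound 2 (1.06 log units; beyond the scatter). Compound 3 `O=C(/C=C/c1cccc(OCc2ccccc2)c1)c1ccccc1` differs from compound 2 by hydrogen in place of nitro on an aromatic carbon. Among the measured compounds shown here, no measured step covers this change directly; the single step known, which swapped a different group for the nitro-bearing ring on the carbonyl carbon, was large, so taking the nitro away is expected to give a step in this assay of a 4.0-fold lower number from compound 2 to compound 3 (0.61 log units; beyond the scatter), toward a lower number. Compound 3 is therefore estimated at 20000 nM, within 7000 nM to 60000 nM.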

Compound 3, half-maximal inhibitory concentration: 25500 nM
Beside the measured number, compound 3's estimate is 1.3-fold (0.11 log units) below it; the range from low to high includes it.
By their numbers in this assay, from the lowest: compound 1; then compound 3; then compound 2.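

With the unsubstituted phenyl as a reference, the earlier comparison of two substituted rings separates into two parts: 4-nitrophenyl to phenyl gives a 3.2-fold lower number from compound 2 to compound 3 (0.50 log units; beyond the scatter) and hydrogen in place of bromo gives a 3.6-fold higher number from compound 1 to compound 3 (0.56 log units; beyond the scatter) in the opposite direction. Among these compounds, nitro therefore stands on the side of weaker inhibition and bromo on the side of stronger inhibition, relative to hydrogen. Nothing at hand explains either direction. Nitro and bromo also sit at different ring positions, so the effect of the group is not separated from that of its place. As far as these compounds go, how an amine or a methoxy group would read on this ring remains open.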